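Swapping the amine on the shared core of compound 2

The source may hold more compounds than are shown below. What is called first, only, known or untested is meant among the compounds shown, and "the series" means these compounds.

Measured so far:
compound 1, `O=C(COc1ccc(C(F)(F)F)cc1)Nc1ccc2nc(N3CCCC3)[nH]c2c1`: 35 nM
compound 2, `CC(C)Nc1nc2ccc(NC(=O)COc3ccc(C(F)(F)F)cc3)cc2n1C`: 70 nM

Both compounds were tested in an assay for displacement of a labelled ligand from melanin-concentrating hormone receptor 1 (Homo sapiens); on this read-out higher numbers stand for weaker inhibition and lower numbers for stronger inhibition. In this assay compound 1 gives 35 nM, and compound 2 gives 70 nM. Compound 2 has the highest number of the two, but its nearest neighbour is compound 1, whose number lies within the usual scatter, so the two values cannot be told apart with confidence. Compound 1 and compound 2 differ in more than one place, so nothing can be said about any single change between them.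

Compound 3, `Cn1c(N2CCCC2)nc2ccc(NC(=O)COc3ccc(C(F)(F)F)cc3)cc21`, has not yet been measured. It differs from compound 2 in one place: pyrrolidin-1-yl in place of isopropylamino on an aromatic carbon. Compound 1 also carries a pyrrolidin-1-yl group on this carbon, and its value sits within the scatter of compound 2, which gives no sign of a large shift in either direction. The step from compound 2 to compound 3 is therefore expected to be small, a 1.4-fold lower number from compound 2 to compound 3 (0.15 log units; within the scatter), with a slight lean toward a lower number. For compound 3 the estimated value in this assay is 50 nM, with a likely range from 15 nM to 150 nM.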

Compound 3, half-maximal inhibitory concentration: 40 nM
Compound 3: middle estimate off by 1.3-fold (0.10 log units), on the high side; the range from low to high includes it.
By their numbers in this assay, from the lowest: compounds 1, 3 and 2 (each within the scatter of the next).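

In this assay the step is a 1.8-fold lower number from compound 2 to compound 3 (0.24 log units; within the scatter) for pyrrolidin-1-yl in place of isopropylamino, so at this position on the shared core, a five-membered ring with no hydrogen-bond donor cannot be told apart from an open group with one donor. Among these compounds, compound 3 also provides the first single-change comparison with compound 1: methyl in place of hydrogen on an aromatic nitrogen gives a 1.1-fold higher number from compound 1 to compound 3 (0.06 log units; within the scatter) and so leaves the value of this assay indistinguishable with or without that methyl, which the earlier pair could not show because it differed in more than one place. No measurement offered here explains why the values stay so close.

Still open, on these data alone, is how piperidin-1-yl, morpholin-4-yl or dimethylamino would read at the same carbon; dimethylamino would be especially informative, as it has no hydrogen-bond donor and no ring, and so would separate those two differences between isopropylamino and pyrrolidin-1-yl. Also open, as far as these compounds go, is whether a longer chain on the aromatic nitrogen, such as ethyl or propyl, would stay as close to these values as methyl does.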